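This account rests on a few compounds, and the source may have more. Where it says the series, first, only, none or still open, it means among the compounds named here.

Among the compounds with values here, in a functional assay on MIA PaCa-2 cells (Homo sapiens) for inhibition, read by MTT assay, with a stated time of 72 h (a lower number here means a stronger inhibitor, a higher number a weaker inhibitor), compound 2 `COc1cc(NC(C)CCCNC(=O)NNC(=O)Nc2cccc(F)c2)c2ncccc2c1` gives 69000 nM, the highest of the two numbers so far, while compound 1 `COc1cc(NC(C)CCCNC(=O)Nc2ccc(F)cc2)c2ncccc2c1` gives 21000 nM. Compound 3 `COc1cc(NC(C)CCCNC(=O)Nc2ccc(C(F)(F)F)cc2)c2ncccc2c1` differs from compound 2 in one place, on an amide-type nitrogen: 4-(trifluoromethyl)phenyl in place of ((3-fluorophenyl)carbamoyl)amino on an amide-type nitrogen. Within the data shown here, the only measured step that bears on this is a 3.3-fold higher number from compound 1 to compound 2 (0.52 log units; beyond the scatter), in which ((3-fluorophenyl)carbamoyl)amino replaced 4-fluorophenyl. The new change removes that same group, so a modest step of similar size towards a lower number is expected, estimated as a 3.8-fold lower number from compound 2 to compound 3 (0.58 log units; beyond the scatter). The estimate for compound 3 is 18000 nM, with an expected range from 7000 nM to 45000 nM.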

Compound 3, half-maximal inhibitory concentration: 8400 nM
For compound 3 the middle estimate is 2.1-fold (0.33 log units) above the measured one; the measured number falls inside the stated range.
By their numbers in this assay, from the lowest: compound 3; then compound 1; then compound 2.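

In this assay, 4-(trifluoromethyl)phenyl in place of ((3-fluorophenyl)carbamoyl)amino on an amide-type nitrogen gives an 8.2-fold lower number from compound 2 to compound 3 (0.91 log units; beyond the scatter). The substituent on the ring also counts, not just the loss of the longer group: trifluoromethyl in place of fluoro on an aromatic carbon gives a 2.5-fold lower number from compound 1 to compound 3 (0.40 log units; beyond the scatter). No measurement offered here accounts for either step.

From the compounds shown here alone, whether a chloro, methoxy or nitrile group on that aromatic carbon would lower the number further remains open. So does whether the trifluoromethyl step would hold with a longer chain in the linker.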